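Ethynyl for ethyl in a thiourea series

The source may report more compounds than this note shows. Statements on the series, on what has been measured and on what is new or still open speak of the compounds shown alone.

Going by the values given here, compound 1 `CC[C@H]1CN2CC[C@H]1C[C@H]2[C@@H](NC(=S)Nc1cc(C(F)(F)F)cc(C(F)(F)F)c1)c1ccnc2ccc(OC)cc12` gives 1300 nM in a functional assay on MES-SA cells (Homo sapiens) for inhibition, read by fluorescence, with a stated time of 144 h (on this read-out lower numbers stand for stronger inhibition and higher numbers for weaker inhibition), the lowest of the two numbers known here; compound 2 `CC[C@H]1CN2CC[C@H]1C[C@H]2[C@@H](Nc1c(NCc2ccccc2)c(=O)c1=O)c1ccnc2ccc(OC)cc12` gives 3100 nM in this assay, a gap beyond the scatter. Compound 3 `C#C[C@H]1CN2CC[C@H]1C[C@H]2[C@@H](NC(=S)Nc1cc(C(F)(F)F)cc(C(F)(F)F)c1)c1ccnc2ccc(OC)cc12` is not yet measured. It differs from compound 1 as follows: ethynyl in place of ethyl on a saturated ring carbon. Among the compounds with values here, no measured pair shows a step of this kind, so the size of the step is uncertain; the expectation is no change beyond the scatter, with no change at the digits printed from compound 1 to compound 3 (within the scatter) as the estimated step. Compound 3 is therefore expected to give about 1300 nM in this assay, within 600 nM to 3000 nM.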

Compound 3, half-maximal inhibitory concentration: 4200 nM
Compound 3: middle estimate off by 3.2-fold (0.51 log units), on the low side; measured number outside the range, above it.
By their numbers in this assay, from the lowest: compound 1; then compounds 2 and 3 (each within the scatter of the next).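

In this assay, ethynyl in place of ethyl on this saturated ring carbon gives a 3.2-fold higher number from compound 1 to compound 3 (0.51 log units; beyond the scatter) and so weaker inhibition, although both groups hold 2 carbon atoms. Going by these compounds alone, the position is therefore not indifferent to the group it carries, at least in the thiourea pair, the only pair that reads it so far. Nothing measured here bears on the reason for this step.

Going by these compounds, whether a vinyl group or a longer chain such as propyl on this carbon stays close to compound 1 remains open. Also open, on these data alone, is whether ethynyl for ethyl gives a similar step on compound 2.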